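This account rests on a few compounds, and the source may have more. Where it says the series, first, only, none or still open, it means among the compounds named here.

Compound 1 `CC(Sc1nc2nn(C3COC3)cc2c(=O)n1-c1ccccc1)c1ccccn1` gives > 1 h in an ADME assay on microsomes from liver (Mus musculus, strain CD-1) for metabolic stability, read by LC-MS, with a stated time of 60 min, tested at 20 uM (on this read-out lower numbers stand for a shorter-lived compound and higher numbers for a longer-lived compound), and this is a limit of the assay, not a number. Compound 2 `CC(Sc1nc2c(cnn2C)c(=O)n1-c1ccccc1)c1cccnc1` gives a true number in this assay, at 0.117 h. Compound 3 `CC(Sc1nc2nn(C3COC3)cc2c(=O)n1-c1ccccc1)c1cccnc1` has not yet been measured. It has the same atoms as compound 1, joined differently, with pyridin-3-yl in place of pyridin-2-yl on a saturated chain carbon bound to a saturated chain carbon and a sulfur. Within the data shown here, no measured pair shows this swap alone, so its size is uncertain. Compound 2 also carries pyridin-3-yl and gives 0.117 h, which points towards a shorter half-life for compound 3. The expected change is an at least 2.5-fold lower number from compound 1 to compound 3 (0.39 log units; beyond the scatter), a drop in this assay that may prove modest. For compound 3 the estimated half-life is 0.4 h, with an expected range from 0.12 h to 1.3 h.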

Compound 3, half-life: 0.045 h
The estimate for compound 3 lay 8.9-fold (0.95 log units) above the measured number, outside the stated range (below it).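

With the rest of the molecule unchanged, the effect of pyridin-3-yl in place of pyridin-2-yl on this saturated chain carbon can now be seen alone, and in this assay it gives an at least 22-fold lower number from compound 1 to compound 3 (1.34 log units; beyond the scatter). The two groups have the same counted atoms, donors and acceptors, yet this swap alone moves the half-life well beyond the scatter. The full size of the step remains unknown because compound 1 sits at a limit of the assay, not at a number: the limit of > 1 h in this assay, at which 1 of the 3 values shown sits.

The compounds shown do not reveal why these two groups differ so sharply, or whether the same gap would appear with the rest of the molecule changed. They also leave open how pyridin-4-yl or a pyrimidinyl ring would behave at this place.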